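From Ethyl to Benzyl on a Sulfur

The compounds below may be only part of what the source reports. "The series", "measured", "known", "first", "only" and "open" are said of these compounds alone.

In a functional assay on HCT-116 cells (Homo sapiens) for inhibition, read by MTT assay, with a stated time of 48 h (on this read-out lower numbers stand for stronger inhibition and higher numbers for weaker inhibition), compound 1 `COc1ccc(-n2c(S)nnc2-c2cc(OC)c(OC)c(OC)c2)cc1` gives > 60000 nM, which is a limit and not a number. Compound 2 `COc1ccc(-n2c(SC)nnc2-c2cc(OC)c(OC)c(OC)c2)cc1` gives > 60000 nM, again a limit. Compound 3 `CCSc1nnc(-c2cc(OC)c(OC)c(OC)c2)n1-c1ccc(OC)cc1` gives > 60000 nM, also a limit. For the measured compounds named here, the series so far therefore rests on (the limit of > 60000 nM in this assay, at which 3 of the 3 values shown sit). Compound 4 `COc1ccc(-n2c(SCc3ccccc3)nnc2-c2cc(OC)c(OC)c(OC)c2)cc1` brings (phenyl in place of methyl on a saturated chain carbon bound to a sulfur), with phenyl in place of methyl on a saturated chain carbon bound to a sulfur. The nearest measured changes are a step that the two limits leave unreadable from compound 1 to compound 2, a step that the two limits leave unreadable from compound 1 to compound 3 and a step that the two limits leave unreadable from compound 2 to compound 3, and none has a readable size. They give no direction, so no step beyond the usual scatter is expected in this assay: the expected step is an at least 1.2-fold lower number from compound 3 to compound 4 (0.07 log units; that floor lies within the scatter). The estimate for compound 4 is 50000 nM, with an expected range of 12000 nM to 120000 nM.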

Compound 4, half-maximal inhibitory concentration: 42400 nM
Compound 4: the middle estimate sits 1.2-fold (0.07 log units) above what was measured; measured number inside the range.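

Benzyl on the sulfur gives the first number in this assay that is not a limit; the steps among the earlier compounds cannot be read, and they rest on a single limit: the limit of > 60000 nM in this assay, at which 3 of the 4 values shown sit. Against those limits, the change reads as an at least 1.4-fold lower number from compound 3 to compound 4 (0.15 log units; that floor lies within the scatter) and an at least 1.4-fold lower number from compound 2 to compound 4 (0.15 log units; that floor lies within the scatter) and an at least 1.4-fold lower number from compound 1 to compound 4 (0.15 log units; that floor lies within the scatter) and each floor leaves the true size of the step unknown.

From the compounds shown here alone, what stays open is whether the phenyl matters or any larger group on the sulfur would serve as well. A longer chain such as hexyl, or phenethyl, on the sulfur could separate the two.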